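The source may hold more compounds than are shown below. What is called first, only, known or untested is meant among the compounds shown, and "the series" means these compounds.

Measured compounds:
Compound 1 `CCCCCCCSC1C2CCC(O2)C1C/C=C\CCCC(=O)O`, in a functional assay on a cell-free system (plasma) for inhibition of thromboxane A2 receptor (Homo sapiens) (a lower number here means a stronger inhibitor, a higher number a weaker inhibitor), compound 1 gives 230000 nM; 35000 nM (2 entries).
Compound 2 `CCCCCCCCSCC1C2CCC(O2)C1C/C=C\CCCC(=O)O`: in this assay compound 2 gives 547000 nM.
Compound 3 `CCCCC(O)CSCC1C2CCC(O2)C1C/C=C\CCCC(=O)O`: in this assay compound 3 gives 19000 nM; 10000 nM (2 entries).

Among the measured compounds shown here, compound 2 carries the largest number of the three; it is the only number recorded for it, two further entries for compound 2 having been reported without a single number. Compound 1 and compound 3 each have several entries, gathered in the several entries of compound 1 in this assay, 230000 nM; 35000 nM (2 entries) and (the several entries of compound 3 in this assay, 19000 nM; 10000 nM (2 entries)), and the spread within each of them shows how much repeated readings of this kind can move.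

Compound 4 `CCSCC1C2CCC(O2)C1C/C=C\CCCC(=O)O` is not yet measured. It differs from compound 2 by hydrogen in place of hexyl on a saturated chain carbon, two bonds along the chain from a sulfur. No step between two measured compounds matches this change, so the expectation rests on the numbers shown alone. Compound 2 is already a weak inhibitor in this assay, and the shortening of the chain gives no clear reason to expect a gain. The step from compound 2 to compound 4 is expected to be a 1.1-fold lower number from compound 2 to compound 4 (0.04 log units; within the scatter), that is, no movement beyond the usual scatter, in either direction. Compound 4 is therefore estimated at 500000 nM in this assay, within a range from 100000 nM to 3000000 nM, with a real chance that only a limit and no number is returned.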

Compound 4, half-maximal inhibitory concentration: 5400 nM
Compound 4: the middle estimate sits 93-fold (1.97 log units) above what was measured; the measured number lies below the stated range.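

In this assay, this position, on a saturated chain carbon, two bonds along the chain from a sulfur, turns out to be sensitive to what it carries: hydrogen in place of hexyl gives a 100-fold lower number from compound 2 to compound 4 (2.01 log units; beyond the scatter). Among the compounds shown here, the earlier compounds offered no step between measured neighbours, so this is the first direct reading of the change, and it shows that the hexyl is not needed for inhibition here and that the octyl-to-ethyl shortening goes with the stronger inhibitor of the pair. Compound 2 and compound 4 each rest on a single number, yet the step is wider than the spread among the repeated entries of compound 1, the widest shown: the several entries of compound 1 in this assay, 230000 nM; 35000 nM (2 entries)

The two compounds mark only the ends of the change, so the compounds shown leave open whether the number falls gradually or abruptly with a propyl or a butyl at this position. They also leave open how a phenyl or an amine placed there would read in this assay, and a single pair gives no cause for the step.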